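Formamidine-to-amine exchange on a pyrazole series

A few compounds are considered here, and "the series" means these few. Any claim that something is new, unique, unknown or untested is made for them only; others in the source may bear on it.

Compound 1 `Nc1cc(-c2ccc(Cl)cc2)nn1-c1cccc(Cl)c1` and compound 3 `CN(C)/C=N/c1cc(-c2ccc(Cl)cc2)nn1-c1cccc(Cl)c1` share one core; compound 2 `CN(C)/C=N/c1c(C=O)c(-c2ccccc2)nn1-c1ccccc1` carries another, and how the two cores differ is not broken down here. In a functional assay on NCI-H226 cells (Homo sapiens) for inhibition, read by MTT assay, with a stated time of 72 h (a higher number here means a weaker inhibitor of growth, a lower number a stronger inhibitor of growth), compound 1 gives 75100 nM, compound 3 gives 75600 nM, and compound 2 gives 31400 nM, the lowest of the three numbers, with both others beyond the scatter from it. The exchange one nitrogen atom in place of a group of 5 heavy atoms (3 carbon, 2 nitrogen; no ring), on an aromatic carbon gave a 1.0-fold lower number from compound 3 to compound 1 (0.00 log units; within the scatter), so the group that leaves and the amino that enters are interchangeable there.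

Compound 4 `Nc1c(C=O)c(-c2ccccc2)nn1-c1ccccc1` is reached from compound 2 by one nitrogen atom in place of a group of 5 heavy atoms (3 carbon, 2 nitrogen; no ring), on an aromatic carbon, the same kind of change. The surroundings differ: in compound 2 the site is next to the ring atom that bears a formyl group and next to the ring atom that bears a phenyl group, where in compound 3 it is next to the ring atom that bears a 3-chlorophenyl group and two ring bonds from the ring atom that bears a 4-chlorophenyl group. With one precedent only, a flat step is expected, a 1.1-fold higher number from compound 2 to compound 4 (0.02 log units; within the scatter), because compound 3 to compound 1 gave a 1.0-fold lower number from compound 3 to compound 1 (0.00 log units; within the scatter). Compound 4 is therefore estimated at 33000 nM, with a range from 14000 nM to 80000 nM.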

Compound 4, concentration for 50% growth inhibition: > 100000 nM
Compound 4: a limit, no number (the forecaster's own chance of this, stated with the estimate: 10%); middle value at least 3.0-fold (0.48 log units) from the limit.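

In this assay the exchange of the formamidine-type group for amino gives an at least 3.1-fold higher number from compound 2 to compound 4 (0.50 log units; beyond the scatter), so the flat result on the core of compound 1 does not carry over to the core of compound 2: the same change on two cores in this assay, a 1.0-fold lower number (0.00 log units; within the scatter) from compound 3 to compound 1 and an at least 3.1-fold higher number (0.50 log units; beyond the scatter) from compound 2 to compound 4, at least 3.2-fold (0.50 log units) apart, beyond the scatter of two such steps

Compound 4 gives > 100000 nM, which is a limit of the assay and not a number, so the true size of the step stays unknown and only its lower bound can be read: the limit of > 100000 nM in this assay, at which 1 of the 4 values shown sits.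

The two cores differ in more than one place, with a formyl group and phenyl groups on one and 3-chlorophenyl and 4-chlorophenyl groups on the other, so this comparison does not show which of these differences goes with the change in outcome.

Open, from the compounds shown here alone, is whether the formyl group is what separates the two outcomes, for instance whether a nitrile or a carboxylic acid at that ring atom would leave the step as it stands on the core of compound 2. Also open, going by these compounds, is how a methylamino group would compare with amino and the leaving group on either core.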